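Methyl in place of hydrogen on the aromatic oxygen

A few compounds are considered here, and "the series" means these few. Any claim that something is new, unique, unknown or untested is made for them only; others in the source may bear on it.

Compound 1 `C=CC[N+](C)(C)c1ccccc1OC`: 2890 nM
Compound 2 `C=C(C)C[N+](C)(C)c1ccccc1O`: > 3000 nM

Of the compounds shown here, two have been measured in a functional assay with Cavia porcellus as the target; on this read-out lower numbers stand for stronger inhibition and higher numbers for weaker inhibition. Compound 1 gives 2890 nM in this assay. For compound 2 this assay reports only a limit, > 3000 nM, not a number. Compound 2 thus has no fixed place among the values; it sits at the limit of > 3000 nM in this assay, at which 1 of the 2 values shown sits.

Compound 3 `C=C(C)C[N+](C)(C)c1ccccc1OC` has not been measured. It differs from compound 2 by methyl in place of hydrogen on an oxygen on an aromatic ring. For the measured compounds named here, no step between two measured compounds carries this same change, so the size of the step in this assay is open; the expectation is a shift no larger than the usual scatter, in either direction. The nearest point of comparison is compound 1, which also bears a methoxy group, with 2890 nM in this assay. Compound 3 is expected at 3500 nM, between 1200 nM and 12000 nM. The expected step is a step that the limit leaves unreadable from compound 2 to compound 3.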

Compound 3, half-maximal inhibitory concentration: > 3000 nM
Compound 3 gave a limit, no number (the forecaster's own chance of this, stated with the estimate: 45%); the middle value lies beyond the limit too.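

In this assay the methoxy counterpart of compound 2, compound 3, also ends at a limit, > 3000 nM, so hydroxy to methoxy on this aromatic oxygen does not produce a readable number. The step across this change cannot be read, while methyl in place of hydrogen on a double-bonded chain carbon bound to a saturated chain carbon gives an at least 1.0-fold higher number from compound 1 to compound 3 (0.01 log units; that floor lies within the scatter), so neither change has a size that can be stated. Most of the values now rest on a single limit: the limit of > 3000 nM in this assay, at which 2 of the 3 values shown sit.

On these data alone, what remains open is whether any group on this oxygen gives a measurable number on the side of stronger inhibition. An ethoxy group or a longer chain there, or an amine in place of the oxygen, could settle that.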